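The source may report more compounds than this note shows. Statements on the series, on what has been measured and on what is new or still open speak of the compounds shown alone.

Of the compounds shown here, three that share one core have been tested in a functional assay on HCT-116 cells (Homo sapiens) for cytotoxicity, read by sulforhodamine B assay, with a stated time of 48 h; on this read-out lower numbers stand for stronger inhibition of growth and higher numbers for weaker inhibition of growth. Compound 1 `ClCc1ccc(Cn2cnc3c(Cl)ncnc32)cc1` gives 1120 nM. Compound 2 `ClCc1cccc(Cn2cnc3c(Cl)nc(Cl)nc32)c1` gives 1620 nM, and compound 3 `Nc1nc(Cl)c2ncn(Cc3ccccc3CCl)c2n1` gives 3980 nM. Compound 1 has the lowest of the three numbers; its nearest neighbour is compound 2, whose value lies within the usual scatter of that of compound 1, so the two cannot be told apart, while compound 3 stands furthest away, beyond the scatter.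

Compound 4 `ClCc1ccc(Cn2cnc3c(Cl)nc(Cl)nc32)cc1` has not yet been measured. It differs from compound 1 in a single place: chloro in place of hydrogen on an aromatic carbon. Going by the values given here, no two measured compounds differ by exactly this change, so nothing among them shows what the step does on its own. Among the compounds with values here, compound 2 carries the same added chloro group on the core, but it also differs from compound 1 elsewhere, so the values of compound 1 and compound 2 show only that two such compounds sit within the scatter of each other.

On that basis, compound 4 is expected to move little from compound 1, by a step of a 1.2-fold higher number from compound 1 to compound 4 (0.06 log units; within the scatter) that stays within the scatter. The estimate for compound 4 in this assay is 1300 nM, with a range from 600 nM to 2800 nM.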

Compound 4, concentration for 50% growth inhibition: 1700 nM
The estimate for compound 4 lay 1.3-fold (0.12 log units) below the measured number; the measured number falls inside the stated range.
By their numbers in this assay, from the lowest: compounds 1, 2 and 4 (each within the scatter of the next); then compound 3.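

In this assay, going by these compounds alone, the step of a 1.5-fold higher number from compound 1 to compound 4 (0.18 log units; within the scatter) gives the first direct reading of this one change, with everything else in the molecule held the same. Chloro in place of hydrogen on this aromatic carbon, between two ring nitrogen atoms, therefore leaves the two compounds indistinguishable in this assay, so the position accepts this added chlorine without a measurable change in growth inhibition. No measurement of any other kind bears on this result.

Within the data shown here, what a methoxy group or a carboxylic acid would do on the same carbon remains open, since chloro is the only group here that can be read there on its own. Going by these compounds, it is also open whether the same step would read alike on a compound that differs elsewhere from compound 1.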